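Benzyl chain extension on the unsubstituted oxindole series

A few compounds are considered here, and "the series" means these few. Any claim that something is new, unique, unknown or untested is made for them only; others in the source may bear on it.

Measured compounds and their values in a functional assay on cells (Cancer cell lines, Homo sapiens) for cytotoxicity, with a stated time of 48 h; a lower number here means a stronger inhibitor of growth, a higher number a weaker inhibitor of growth:
compound 1, `O=C1Nc2ccccc2/C1=C\c1c(Cl)n(Cc2ccccc2)c2ccccc12`, 20400 nM
compound 2, `COc1cc2c(/C=C3/C(=O)Nc4ccc(Cl)cc43)c(Cl)n(Cc3cc(OC)c(OC)c(OC)c3)c2cc1C`, 1780 nM
compound 3, `COc1cc2c(/C=C3/C(=O)Nc4cccc(Cl)c43)c(Cl)n(Cc3cc(OC)c(OC)c(OC)c3)c2cc1C`, 1910 nM

Compound 1 gives the highest number of the three in this assay, and its gap to both compound 2 and compound 3 lies well beyond the scatter. Within the data shown here, compound 2 and compound 3 sit within the scatter of each other, as the single measured step shows: a 1.1-fold higher number from compound 2 to compound 3 (0.03 log units; within the scatter). That step concerns the placement of the chlorine on the oxindole part and says nothing about the substituent on the indole nitrogen.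

Compound 4, `O=C1Nc2ccccc2/C1=C\c1c(Cl)n(CCCc2ccccc2)c2ccccc12`, differs from compound 1 by phenethyl in place of phenyl on a saturated chain carbon bound to an aromatic nitrogen. Among the measured compounds shown here, no measured pair in this set changes the length of the chain between the aromatic nitrogen and the phenyl ring, so no step bears directly on this change. Compound 2 and compound 3 carry a different nitrogen substituent altogether, together with several other changes, so their lower numbers cannot be assigned to any single alteration.

With nothing to indicate a direction, the expected step is a 1.0-fold lower number from compound 1 to compound 4 (0.01 log units; within the scatter), that is, none beyond the scatter. Compound 4 is therefore estimated at 20000 nM, with a range of 5000 nM to 60000 nM.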

Compound 4, concentration for 50% growth inhibition: 19100 nM
Estimate against measurement, compound 4: 1.0-fold (0.02 log units) above, within the range that was stated.
By their numbers in this assay, from the lowest: compounds 2 and 3 (each within the scatter of the next); then compounds 4 and 1 (each within the scatter of the next).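

In this assay, among these compounds, this is the first measured change in the length of the chain on the aromatic nitrogen, and it gives a 1.1-fold lower number from compound 1 to compound 4 (0.03 log units; within the scatter), which leaves the two compounds within the scatter of each other. On the core of compound 1, benzyl and 3-phenylpropyl are therefore not told apart at this position, something the earlier step, a 1.1-fold higher number from compound 2 to compound 3 (0.03 log units; within the scatter), could not show, as it concerns a different place on the molecule. No measurement here offers an explanation for this flat result.

As far as these compounds go, whether the flat result holds for a shorter or longer chain, or for a chain ending in an amine or a carboxylic acid in place of the phenyl ring, remains open. Also open, from the compounds shown here alone, is how much of the gap between compound 1 and the lower numbers of compound 2 and compound 3 belongs to the nitrogen substituent, as those compounds differ from compound 1 in several places at once and no single change can be isolated.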